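A ring swap from compound 2 to compound 3

The source may report more compounds than this note shows. Statements on the series, on what has been measured and on what is new or still open speak of the compounds shown alone.

Measured so far:
compound 1 `COc1ccc(/C=N\NC(=S)NC(C)(C)CCC[C@](C)(O)[C@@H]2CC=C(C)CC2)cc1`: 48500 nM
compound 2 `CC1=CC[C@@H]([C@@](C)(O)CCCC(C)(C)NC(=S)N/N=C\c2cccc([N+](=O)[O-])c2)CC1`: 49300 nM

In a functional assay on UACC-62 cells (Homo sapiens) for cytotoxicity, read by sulforhodamine B assay (a lower number here means that less compound is tolerated, a higher number that more compound is tolerated), compound 1 gives 48500 nM, and compound 2 gives 49300 nM. Compound 2 holds the higher of the two numbers, but its nearest neighbour is compound 1, and the step of a 1.0-fold higher number from compound 1 to compound 2 (0.01 log units; within the scatter) lies within the scatter, so the two compounds cannot be told apart on these data.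

Compound 3 `CC1=CC[C@@H]([C@@](C)(O)CCCC(C)(C)NC(=S)N/N=C\c2ccccc2Cl)CC1` has not been measured. It differs from compound 2 as follows: 2-chlorophenyl in place of 3-nitrophenyl on a carbon with a double bond to nitrogen. Going by the values given here, the only measured step that bears on this change is the one in which the ring on the same carbon was exchanged, a 1.0-fold higher number from compound 1 to compound 2 (0.01 log units; within the scatter), and that exchange left the number essentially unchanged. On that basis the step from compound 2 to compound 3 is expected to be a 1.0-fold lower number from compound 2 to compound 3 (0.00 log units; within the scatter), with no change beyond the scatter. Compound 3 is therefore estimated at 49000 nM, with a range from 20000 nM to 120000 nM.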

Compound 3, concentration lethal to 50% of the cells: > 100000 nM
Compound 3 was reported as a limit; the forecaster's own chance of this, stated with the estimate: 10%; middle value at least 2.0-fold (0.30 log units) from the limit.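

In this assay, the result for compound 3 is a limit and not a number: the limit of > 100000 nM in this assay, at which 1 of the 3 values shown sits. Even so, it gives an at least 2.0-fold higher number from compound 1 to compound 3 (0.31 log units; beyond the scatter), whereas the floor of an at least 2.0-fold higher number from compound 2 to compound 3 (0.30 log units; that floor lies within the scatter) does not by itself separate the 2-chlorophenyl compound from the 3-nitrophenyl one. The ring on this carbon therefore does not always leave the number in place as the earlier exchange did: with 2-chlorophenyl in place of 4-methoxyphenyl, more compound is tolerated, though this rests on a single pair.

The compounds shown leave open how far the true number of compound 3 lies past its limit, and whether the chlorine or the ring as a whole goes with the change. They also do not tell how a ring carrying an amine or a carboxylic acid would read in this assay.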